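The compounds below may be only part of what the source reports. "The series", "measured", "known", "first", "only" and "open" are said of these compounds alone.

Measured compounds in a functional assay on HCT-116 cells (Homo sapiens) for inhibition, read by sulforhodamine B assay, with a stated time of 48 h, tested at 50 uM; a lower number here means less inhibition of growth, a higher number more inhibition of growth at the concentration tested:
compound 1, `COc1ccccc1/C=C/C(=O)/C=C/c1ccc(OCc2cn(CCOc3cc(=O)oc4ccccc34)nn2)c(OC)c1`: compound 1 gives 70%
compound 2, `COc1cc(/C=C/C(=O)/C=C/c2cccc3ccccc23)ccc1OCc1cn(CCCOc2cc(=O)oc3ccccc23)nn1`: compound 2 gives 66%

For the measured compounds named here, compound 1 holds the higher of the two numbers measured so far. Its nearest neighbour is compound 2, whose value sits within the usual scatter of that of compound 1, so the two numbers cannot be put in order. Going by the values given here, compound 2 also differs from compound 1 in more than one place, so the two values show only that both compounds reach a similar level of growth inhibition at the tested concentration.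

Compound 3, `COc1cc(/C=C/C(=O)/C=C/c2cccs2)ccc1OCc1cn(CCOc2cc(=O)oc3ccccc23)nn1`, has not yet been measured in this assay. It differs from compound 1 in one place: thiophen-2-yl in place of 2-methoxyphenyl on a double-bonded chain carbon bound to a double-bonded chain carbon. Among the compounds with values here, no pair of measured compounds differing in a single place is available, so the size of such a change at this position has not been tested here. On what the two measured compounds show, a small step downward, or none beyond the scatter, is expected in this assay for the change from compound 1 to compound 3, as a number 8 percentage points lower from compound 1 to compound 3 (within the scatter). Compound 3 is therefore estimated to reach 62%, with a range from 45% to 78%.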

Compound 3, percent growth inhibition at one concentration: 71%
Compound 3: middle estimate off by 9 percentage points, on the low side, within the range that was stated.
By their numbers in this assay, from the lowest: compounds 2, 1 and 3 (each within the scatter of the next).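

In this assay, thiophen-2-yl in place of 2-methoxyphenyl on a double-bonded chain carbon bound to a double-bonded chain carbon gives a number 1 percentage points higher from compound 1 to compound 3 (within the scatter), and this pair gives the only reading of a single-place difference among the compounds shown. At this position, then, the 2-methoxyphenyl group, with its 8 heavy atoms and six-membered aromatic ring of carbon only, and the thiophen-2-yl group, with its 5 heavy atoms and five-membered aromatic ring with 1 hetero atom, give numbers that cannot be told apart at the tested concentration. No evidence is available that would explain this result.

Going by these compounds, whether the same level of growth inhibition would hold with a phenyl ring carrying an amine or a carboxylic acid at this position remains open. A reading at one concentration also leaves open how compound 1 and compound 3 would compare across a range of concentrations, and whether the two groups would again give indistinguishable numbers on a core with a longer chain.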